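From 3,4-Dichlorophenyl to 2,3-Dichlorophenyl

This account rests on a few compounds, and the source may have more. Where it says the series, first, only, none or still open, it means among the compounds named here.

Measured in a functional assay on HepG2 cells (Homo sapiens) for cytotoxicity, read by MTT assay, with a stated time of 72 h; on this read-out higher numbers stand for weaker inhibition and lower numbers for stronger inhibition:
- compound 1 `CNC(=O)c1cc(Oc2ccc(C3=NNC(c4ccc(F)cc4Cl)C3)cc2)ccn1`: 11500 nM
- compound 2 `CNC(=O)c1cc(Oc2ccc(C3=NNC(c4cccc([N+](=O)[O-])c4)C3)cc2)ccn1`: 26500 nM
- compound 3 `CNC(=O)c1cc(Oc2ccc(C3=NNC(c4ccc(Cl)c(Cl)c4)C3)cc2)ccn1`: 14400 nM

Compound 3 cannot be told apart from either of the other two compounds: the record shows a 1.3-fold higher number from compound 1 to compound 3 (0.10 log units; within the scatter) and a 1.8-fold lower number from compound 2 to compound 3 (0.26 log units; within the scatter). Compound 4 `CNC(=O)c1cc(Oc2ccc(C3=NNC(c4cccc(Cl)c4Cl)C3)cc2)ccn1` is the next case, with 2,3-dichlorophenyl in place of 3,4-dichlorophenyl on a saturated ring carbon. The two compounds have the same atoms, joined differently.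

All three measured steps exchange the group at this same carbon. The only one that leaves the scatter is a 2.3-fold higher number from compound 1 to compound 2 (0.36 log units; beyond the scatter), a modest step that brings in 3-nitrophenyl, a group absent from compound 4. The exchange between the two chlorine-bearing groups gave a 1.3-fold higher number from compound 1 to compound 3 (0.10 log units; within the scatter), which is the closer precedent. Within the data shown here, no measured pair shows the effect of moving chlorine alone, so this precedent is only indirect. On this evidence, no step beyond the scatter is expected in this assay, and no clear direction can be assigned. The estimated change is a 1.1-fold lower number from compound 3 to compound 4 (0.04 log units; within the scatter). The estimate for compound 4 is 13000 nM, with an expected range from 6500 nM to 26000 nM.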

Compound 4, half-maximal inhibitory concentration: 4990 nM
For compound 4 the middle estimate is 2.6-fold (0.42 log units) above the measured one; the measured number lies below the stated range.
By their numbers in this assay, from the lowest: compound 4; then compounds 1, 3 and 2 (each within the scatter of the next, the first and the last beyond it).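

In this assay, the arrangement of the chlorines on this saturated ring carbon's phenyl group matters on its own. Among these compounds, with the same atoms joined differently, 2,3-dichlorophenyl in place of 3,4-dichlorophenyl gives a 2.9-fold lower number from compound 3 to compound 4 (0.46 log units; beyond the scatter), whereas the earlier exchanges left only one step beyond the scatter, the one between compound 1 and compound 2. Compound 4 also separates from both other compounds, with a 2.3-fold lower number from compound 1 to compound 4 (0.36 log units; beyond the scatter) and a 5.3-fold lower number from compound 2 to compound 4 (0.73 log units; beyond the scatter), which makes it the strongest inhibitor of the four on this read-out, although every step to it is modest, and nothing available here accounts for the gain.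

The compounds shown leave open whether the lower number belongs to chlorine itself or would persist with bromine or methyl in the same two places on the phenyl ring. They also leave open how this position would respond to an amine or a carboxylic acid on that ring, since all four groups shown are substituted phenyl rings carrying only chlorine, fluorine or nitro.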